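Camphor hydrazones: toxicity toward canine kidney cells

The source may hold more compounds than are shown below. What is called first, only, known or untested is meant among the compounds shown, and "the series" means these compounds.

Compound 2 `CC1(C)[C@@H]2CC[C@@]1(C)/C(=N/NC(=O)C(F)(F)F)C2` belongs to a small set of hydrazones built on one shared core, among them compound 1 `CC12C=CC3(O1)C(C(=O)N1CCSC13)C2C(=O)N/N=C1\C[C@H]2CC[C@]1(C)C2(C)C`, compound 3 `CCCC(=O)N/N=C1\C[C@H]2CC[C@]1(C)C2(C)C` and the not yet measured compound 4 `CC1(C)[C@@H]2CC[C@@]1(C)/C(=N/NC(=O)c1ccccc1)C2`. In an ADME assay on MDCK cells (Canis lupus familiaris) for cytotoxicity, read by MTT assay, with a stated time of 48 h (on this read-out higher numbers stand for lower toxicity in this test and lower numbers for higher toxicity in this test), compound 2 gives only a limit, > 1070000 nM. In this assay compound 3 likewise gives only a limit, > 1190000 nM. For compound 1 this assay reports "not determined" (no result reported). Compound 2 therefore stands at a limit rather than a number, with one further limit and one entry without a number beside it.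

The change from compound 2 to compound 4 is phenyl in place of trifluoromethyl on a carbonyl carbon. For the measured compounds named here, the only measured step nearby is a step that the two limits leave unreadable from compound 2 to compound 3, whose size the two limits leave unreadable, as the limit of > 1070000 nM in this assay, at which 1 of the 3 values shown sits, and the limit of > 1190000 nM in this assay, at which 1 of the 3 values shown sits, show. Going by the values given here, no measured step in this assay is readable, so no size of step in either direction can be predicted for the change to compound 4; the account expects no change beyond the scatter, and both limits point toward a value again at or beyond the top of the tested range.

The account therefore estimates that compound 4 in this assay will give about 1000000 nM, within a range from 300000 nM to 3000000 nM. The step expected from compound 2 to compound 4 is an at least 1.0-fold lower number from compound 2 to compound 4 (0.02 log units; that floor lies within the scatter).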

Compound 4, half-maximal cytotoxic concentration: > 1040000 nM
Compound 4: only a limit was reported (the forecaster's own chance of this, stated with the estimate: 70%); middle value at least 1.0-fold (0.01 log units) from the limit.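

Compound 2, compound 3 and compound 4 each give only a limit in this assay, so none of the steps among them can be read. The compounds shown leave open where any of the three would give an actual number, and whether trifluoromethyl, propyl or phenyl on the carbonyl carbon changes the read-out at all.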